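The source may hold more compounds than are shown below. What is called first, only, known or untested is meant among the compounds shown, and "the series" means these compounds.

Compound 3 `CC(=O)OC[C@H]1O[C@H](OC[C@@H](Cn2cc(CN(c3nc(-c4ccc([N+](=O)[O-])cc4)no3)C3CCCCC3)nn2)OC(C)=O)C=C[C@@H]1OC(C)=O` gives 64.1 ug/mL in an ADME assay on RAW264.7 cells (Mus musculus) for cytotoxicity, read by MTT assay, with a stated time of 48 h (a lower number here means that less compound is tolerated, a higher number that more compound is tolerated), the highest of the three numbers measured, although its gaps to compound 1 and compound 2 both fall within the scatter. Compound 1 `C#CCN(c1nc(-c2cccc([N+](=O)[O-])c2)no1)C1CCCCC1` gives 34.2 ug/mL in this assay, and compound 2 `C#CCN(c1nc(-c2ccccc2)no1)C1CCCCC1` gives 32.1 ug/mL. Compound 4 `COc1ccc(-c2noc(N(Cc3cn(C[C@H](CO[C@@H]4C=C[C@H](OC(C)=O)[C@@H](COC(C)=O)O4)OC(C)=O)nn3)C3CCCCC3)n2)cc1` differs from compound 3 by methoxy in place of nitro on an aromatic carbon. Within the data shown here, the single measured step that bears on this, a 1.1-fold lower number from compound 1 to compound 2 (0.03 log units; within the scatter), also removed a nitro group from an aromatic carbon and stayed within the scatter. A step of comparable size, with no direction beyond the scatter, is therefore expected when methoxy replaces nitro. Compound 4 is thus estimated at 60 ug/mL, with a range from 30 ug/mL to 120 ug/mL. The expected step is a 1.1-fold lower number from compound 3 to compound 4 (0.03 log units; within the scatter).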

Compound 4, half-maximal cytotoxic concentration: 86.3 ug/mL
For compound 4 the middle estimate is 1.4-fold (0.16 log units) below the measured one; low and high end bracket the measured number.
By their numbers in this assay, from the lowest: compounds 2, 1, 3 and 4 (each within the scatter of the next, the first and the last beyond it).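

In this assay, exchanging 4-nitrophenyl for 4-methoxyphenyl gives a 1.3-fold higher number from compound 3 to compound 4 (0.13 log units; within the scatter), so this exchange on an aromatic carbon para to a large group stays within the scatter. The earlier step, a 1.1-fold lower number from compound 1 to compound 2 (0.03 log units; within the scatter), covered only loss of nitro to hydrogen on the smaller core of compound 1, whereas this one puts methoxy in its place on the larger core of compound 3. No measurement on hand accounts for either step. Open, from the compounds shown here alone, is whether an amine or a carboxylic acid at this position would also stay within the scatter.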